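The source may hold more compounds than are shown below. What is called first, only, known or untested is meant among the compounds shown, and "the series" means these compounds.

Compound 1 `CC(C(=O)NCc1ccc(C(F)(F)F)cc1N1CCCC1)c1ccc(NS(C)(=O)=O)c(F)c1` is the reference here. Among the measured compounds shown here, in an assay on CHO cells for antagonist activity at transient receptor potential cation channel subfamily V member 1 (Homo sapiens), read by FLIPR (a higher number here means a weaker inhibitor, a lower number a stronger inhibitor), compound 1 gives 2.3 nM, the higher of the two numbers measured so far; compound 2 `CC(C(=O)NCc1ccc(C(F)(F)F)cc1N1CCC(c2ccc(F)cc2)CC1)c1ccc(NS(C)(=O)=O)c(F)c1` gives 0.9 nM, a gap that lies beyond the scatter. Compound 3 `CCCOc1cc(C(F)(F)F)ccc1CNC(=O)C(C)c1ccc(NS(C)(=O)=O)c(F)c1` has not been measured. It differs from compound 1 in one place: propoxy in place of pyrrolidin-1-yl on an aromatic carbon. For the measured compounds named here, no measured pair shows this kind of change, so the step can only be guessed. The expectation is a modest weakening, a 3.5-fold higher number from compound 1 to compound 3 (0.54 log units; beyond the scatter), in this assay. Compound 3 is therefore estimated at 8 nM, within a range of 2 nM to 30 nM.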

Compound 3, inhibition constant: 2 nM
For compound 3 the middle estimate is 4.0-fold (0.60 log units) above the measured one; the measured number falls inside the stated range.
By their numbers in this assay, from the lowest: compound 2; then compounds 3 and 1 (each within the scatter of the next).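

In this assay, propoxy in place of pyrrolidin-1-yl on this aromatic carbon gives a 1.2-fold lower number from compound 1 to compound 3 (0.06 log units; within the scatter), so the exchange of the ring and its nitrogen for an open chain with an oxygen leaves no difference beyond the scatter. For this pair, then, neither the five-membered ring nor the nitrogen is needed to reach the level of compound 1. No measurement available here bears on why the two groups read alike.

Still open, as far as these compounds go, is how a shorter chain such as ethoxy or a longer one such as butoxy reads on this carbon. An open-chain amine such as dimethylamino is equally untested among the compounds shown.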